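The source may hold more compounds than are shown below. What is called first, only, known or untested is meant among the compounds shown, and "the series" means these compounds.

Values in a physicochemical assay for lipophilicity, using the shake flask method, measured as octanol-water partition, at pH 7.4; a higher number here means a more lipophilic compound, a lower number a more polar compound:
- compound 1 `CC(C)n1cc(-c2ccnc3[nH]c(C4CCNCC4)cc23)ccc1=O`: -0.2
- compound 2 `COc1cc(F)ccc1-c1ccnc2[nH]c(C3CCN(CC(=O)N(C)C)CC3)cc12`: 2.9

Compound 2, at 2.9, is the higher of the two, and the gap to compound 1 lies beyond the scatter. The next compound to be measured is compound 3 `CC(C)n1nc(-c2ccnc3[nH]c(C4CCN(CC(=O)N(C)C)CC4)cc23)ccc1=O`. The change is a group of 10 heavy atoms (7 carbon, 2 nitrogen, 1 oxygen; one six-membered aromatic ring with 2 hetero atoms) in place of a group of 9 heavy atoms (7 carbon, 1 oxygen, 1 fluorine; one six-membered aromatic ring of carbon only), on an aromatic carbon, on an aromatic carbon of a six-membered aromatic ring with 1 nitrogen, opposite the ring nitrogen.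

Going by the values given here, no measured step isolates this change. Among the compounds with values here, the only guide is compound 1 at -0.2, which differs from compound 2 in more than one place, so it suggests a direction but not a size. A fall beyond the scatter is expected in this assay. The estimated change is a number 1.30 log units lower from compound 2 to compound 3 (beyond the scatter). For compound 3 the expected value is 1.6, with an estimated range of 1 to 2.2.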

Compound 3, distribution coefficient: 2
Compound 3: middle estimate off by 0.40 log units, on the low side; the measured number falls inside the stated range.
By their numbers in this assay, from the lowest: compound 1; then compound 3; then compound 2.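

In this assay, going by these compounds alone, the 4-fluoro-2-methoxyphenyl group, opposite the ring nitrogen, gives way to a group with a six-membered aromatic ring with 2 hetero atoms and 1 double bond outside aromatic rings, and the result is a number 0.90 log units lower from compound 2 to compound 3 (beyond the scatter), the first reading of a change made in one place. This position alone therefore moves the read-out beyond the scatter, although the value stays well apart from the low figure of compound 1, which differs from both other compounds in more than one place, so those pairs cannot be read as steps. No measurement in hand accounts for the size of this step.

One step cannot show whether a plain phenyl or a pyridine ring at this position would give a value nearer compound 2 or compound 3. Going by these compounds, whether the step keeps its size with a free amine on the other side of the core also remains open.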